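One More Carbon on the Carbonyl Side Chain

A few compounds are considered here, and "the series" means these few. Any claim that something is new, unique, unknown or untested is made for them only; others in the source may bear on it.

Of the compounds shown here, two sharing one core have been measured so far. In a physicochemical assay for solubility, read by HPLC, in phosphate buffer, measured as kinetic solubility, at pH 7.4 (on this read-out lower numbers stand for lower solubility and higher numbers for higher solubility), compound 1 `CC(=O)c1cc(-c2ccc(S(N)(=O)=O)cc2)n(-c2ccc(Cl)cc2)n1` gives 86800 nM, and compound 2 `NS(=O)(=O)c1ccc(-c2cc(C(=O)C3CCCC3)nn2-c2ccc(Cl)cc2)cc1` gives 4600 nM, the lower of the two numbers.

Compound 3 `NS(=O)(=O)c1ccc(-c2cc(C(=O)CC3CCCC3)nn2-c2ccc(Cl)cc2)cc1` differs from compound 2 at a single place: cyclopentylmethyl in place of cyclopentyl on a carbonyl carbon. In plain terms, cyclopentylmethyl stands in place of cyclopentyl on a carbonyl carbon, and the five-membered ring of carbon remains.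

For the measured compounds named here, only one measured step bears on this change, and it involves the same carbonyl carbon. That step, with cyclopentyl in place of methyl, reads a 19-fold lower number from compound 1 to compound 2 (1.28 log units; beyond the scatter), which is large and beyond the scatter. Going by the values given here, a single step is thin evidence, and no measured pair shows the exact change from cyclopentyl to cyclopentylmethyl. A further move toward a lower number in this assay is expected, but a much smaller one. The expected change is a 1.8-fold lower number from compound 2 to compound 3 (0.26 log units; within the scatter), an estimated step that stays within the scatter. For compound 3 the estimated value is 2500 nM, with an expected range from 800 nM to 6500 nM.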

Compound 3, solubility: 2600 nM
Compound 3: middle estimate off by 1.0-fold (0.02 log units), on the low side, and the stated range covers the measured number.
By their numbers in this assay, from the lowest: compounds 3 and 2 (each within the scatter of the next); then compound 1.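

Placing cyclopentylmethyl (6 heavy atoms) in place of cyclopentyl (5 heavy atoms) on a carbonyl carbon gives a 1.8-fold lower number from compound 2 to compound 3 (0.25 log units; within the scatter) in this assay and so does not separate compound 2 from compound 3. This is the first sign that, among these three compounds, the side chain's size does not track the read-out evenly: the large step came with the switch from methyl to the five-membered ring of carbon, a 19-fold lower number from compound 1 to compound 2 (1.28 log units; beyond the scatter) and the two-step total is a 33-fold lower number from compound 1 to compound 3 (1.52 log units; beyond the scatter) across the series. Once that ring is present in both compounds, the added length of cyclopentylmethyl leaves the number within the usual scatter, and nothing measured here accounts for this result.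

The compounds shown leave open whether a longer chain carrying the same ring would also stay within the scatter of compound 3, or whether the number would move clearly beyond it. They also leave open what an amine or a carboxylic acid on this side chain would give in this assay when placed on the same carbonyl carbon.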